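The source may report more compounds than this note shows. Statements on the series, on what has been measured and on what is new or still open speak of the compounds shown alone.

Working notes on the series. Of the compounds shown here, two so far have numbers in a functional assay on the whole organism (integument) for inhibition, with Chilo suppressalis as the target, read by scintillation counting, with a stated time of 72 h, in the presence of a further agent that is not named here; a lower number here means a stronger inhibitor, a higher number a weaker inhibitor. Compound 1 `COc1cccc(OC)c1C(=O)Nc1nnc(-c2ccc(C(C)C)cc2)s1` gives 182 nM. Within the data shown here, compound 2 `CCOc1ccc(-c2nnc(NC(=O)c3c(OC)cccc3OC)s2)cc1` gives 95.5 nM, the lower of the two numbers; the only measured step, a 1.9-fold lower number from compound 1 to compound 2 (0.28 log units; within the scatter), lies inside the scatter, so no order between compound 2 and compound 1 can be read from it. Compound 3 `COc1cccc(OC)c1C(=O)Nc1nnc(-c2ccc(-c3ccccc3)cc2)s1` is not yet measured. It differs from compound 2 in one place: phenyl in place of ethoxy on an aromatic carbon. Among the measured compounds shown here, no measured step exchanges ethoxy for phenyl, so nothing bears directly on this change; the single known step concerns a different pair of groups and is itself within the scatter. The step from compound 2 is therefore expected to be small, a 1.2-fold higher number from compound 2 to compound 3 (0.06 log units; within the scatter), with no settled direction beyond the scatter. The estimate for compound 3 in this assay is 110 nM, with a range from 40 nM to 350 nM.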

Compound 3, half-maximal inhibitory concentration: 117 nM
For compound 3 the middle estimate is 1.1-fold (0.03 log units) below the measured one, within the range that was stated.
By their numbers in this assay, from the lowest: compounds 2, 3 and 1 (each within the scatter of the next).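

In this assay the position on an aromatic carbon para to a large group accepts a whole six-membered aromatic ring in place of ethoxy without a change that can be read: a 1.2-fold higher number from compound 2 to compound 3 (0.09 log units; within the scatter). Among these compounds, the comparison with isopropyl gives the same picture, a 1.6-fold lower number from compound 1 to compound 3 (0.19 log units; within the scatter), so isopropyl, ethoxy and phenyl, which differ in heavy-atom count, ring content and hydrogen-bond acceptors, all lie within the scatter of one another, where the earlier compounds covered only two groups without a ring. Nothing available explains this flat response at the position.

From the compounds shown here alone, whether an amine, a carboxylic acid or a longer alkoxy chain at this position would move the number beyond the scatter remains open. The compounds shown also say nothing about changes on the dimethoxy-substituted side of the shared core.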